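Swapping a ring ester for a carbamate-bearing amine

The source may hold more compounds than are shown below. What is called first, only, known or untested is meant among the compounds shown, and "the series" means these compounds.

Measured compounds:
Compound 1, `CCOC(=O)C1CCN(C(=O)CN2CN(c3ccccc3)C3(CCN(C(=O)c4ccc(C5CCCCC5)cc4)CC3)C2=O)CC1`, gives 900 nM.
Compound 2, `CCC1CCCN(C(=O)CN2CN(c3ccccc3)C3(CCN(C(=O)c4ccc(C5CCCCC5)cc4)CC3)C2=O)C1`, gives 2600 nM.
Compound 3, `COC(=O)CCCNC(=O)CN1CN(c2ccccc2)C2(CCN(C(=O)c3ccc(C4CCCCC4)cc3)CC2)C1=O`, gives 2500 nM.

All three share the core of compound 1 and differ only in the amine attached to one carbonyl carbon. In an assay on HEK293 cells for displacement of a labelled ligand from NPC1-like intracellular cholesterol transporter 1 (Homo sapiens) (a lower number here means a stronger inhibitor, a higher number a weaker inhibitor), compound 1 stands lowest of the three numbers, that is, it is the strongest inhibitor among them. The step of a 2.9-fold higher number from compound 1 to compound 2 (0.46 log units; beyond the scatter) and the step of a 2.8-fold higher number from compound 1 to compound 3 (0.44 log units; beyond the scatter) both point the same way, each a modest loss. Between the two weaker compounds the step is a 1.0-fold lower number from compound 2 to compound 3 (0.02 log units; within the scatter), so they cannot be told apart.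

Compound 4, `CC(C)(C)OC(=O)NC1CCN(C(=O)CN2CN(c3ccccc3)C3(CCN(C(=O)c4ccc(C5CCCCC5)cc4)CC3)C2=O)CC1`, has not been measured. It differs from compound 1 in one place: (tert-butoxycarbonyl)amino in place of ethoxycarbonyl on a saturated ring carbon. The six-membered non-aromatic ring with one nitrogen is kept, unlike in compound 2 and compound 3, where the whole amine portion was exchanged. Both measured steps bear on this change only loosely, since they altered more than the group on the ring carbon; each was modest and upward. A smaller step in the same direction, or none beyond the scatter, is therefore expected in this assay. For compound 4 the expected value is 1500 nM, with a range from 600 nM to 4000 nM. The estimated step is a 1.7-fold higher number from compound 1 to compound 4 (0.22 log units; within the scatter).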

Compound 4, half-maximal inhibitory concentration: 4800 nM
Compound 4: the middle estimate sits 3.2-fold (0.51 log units) below what was measured; the measured number lies above the stated range.
By their numbers in this assay, from the lowest: compound 1; then compounds 3, 2 and 4 (each within the scatter of the next).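

The ring itself is kept in this change, and the group on the saturated ring carbon alone still moves the result in this assay: swapping ethoxycarbonyl for (tert-butoxycarbonyl)amino gives a 5.3-fold higher number from compound 1 to compound 4 (0.73 log units; beyond the scatter). So the loss seen earlier does not require exchanging the whole amine portion, and compound 1 remains the strongest inhibitor of the four. No measurement shown here explains why this swap costs binding strength.

The swap enlarges the group and adds a hydrogen-bond donor at the same time, so the compounds shown do not tell which of these differences goes with the loss. A smaller (methoxycarbonyl)amino group, a free amine or a carboxylic acid on the same ring carbon would help pull these differences apart.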